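A Thiophene Ring in Place of a Chlorophenyl Ring

This account rests on a few compounds, and the source may have more. Where it says the series, first, only, none or still open, it means among the compounds named here.

Within the data shown here, compound 2 `CC1=CC[C@H](C(C)(C)NC(=S)N/N=C/c2ccccc2Cl)CC1` gives the higher of the two numbers measured so far in a functional assay on OVCAR-3 cells (Homo sapiens) for inhibition, read by sulforhodamine B assay, with a stated time of 48 h (on this read-out higher numbers stand for weaker inhibition of growth and lower numbers for stronger inhibition of growth), namely 83600 nM. Compound 1 `CC1=CC[C@H](C(C)(C)NC(=S)N/N=C/c2ccccc2)CC1`, which carries a plain phenyl ring at the same position, gives 20600 nM in this assay. Among the measured compounds shown here, the one measured step, a 4.1-fold higher number from compound 1 to compound 2 (0.61 log units; beyond the scatter), is the only guide available. Compound 3 `CC1=CC[C@H](C(C)(C)NC(=S)N/N=C/c2cccs2)CC1` differs from compound 2 in that (thiophen-2-yl in place of 2-chlorophenyl on a carbon with a double bond to nitrogen). The chlorine present in compound 2 thereby leaves together with the whole ring it sat on, so the step that adds chlorine bears here, read in reverse. It was modest, and the thiophene ring is a new piece for which nothing has been measured. A lower number than that of compound 2 is expected for compound 3. The expected step is a 2.8-fold lower number from compound 2 to compound 3 (0.45 log units; beyond the scatter). Compound 3 is estimated at 30000 nM, within a range from 10000 nM to 90000 nM.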

Compound 3, concentration for total growth inhibition: 35100 nM
The estimate for compound 3 lay 1.2-fold (0.07 log units) below the measured number; the measured number falls inside the stated range.
By their numbers in this assay, from the lowest: compounds 1 and 3 (each within the scatter of the next); then compound 2.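

In this assay, replacing the 2-chlorophenyl ring with thiophen-2-yl gives a 2.4-fold lower number from compound 2 to compound 3 (0.38 log units; beyond the scatter) at this carbon with a double bond to nitrogen. This position therefore accepts a five-membered aromatic ring with a sulfur atom in place of a six-membered ring of carbon only, and the plain phenyl comparison gives a 1.7-fold higher number from compound 1 to compound 3 (0.23 log units; within the scatter) with no difference that can be read between the two rings, so among these compounds only compound 2, with its chlorine, stands apart. Nothing measured on these compounds accounts for the numbers.

Going by these compounds, it remains open whether a chlorine on the thiophen-2-yl ring would raise the number as it does on the phenyl ring. Also open, on these data alone, is how this position would respond to a ring carrying an amine or a carboxylic acid.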